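Moving the chlorine on the aryl-substituted core

A few compounds are considered here, and "the series" means these few. Any claim that something is new, unique, unknown or untested is made for them only; others in the source may bear on it.

Compound 1 `COc1n[nH]c2ncc(C#Cc3c(F)ccc(NS(=O)(=O)c4cccnc4)c3F)cc12` gives 1280 nM in a functional assay on HCT-116 cells (Homo sapiens) for antiproliferative activity, read by MTT assay, with a stated time of 68 h; a higher number here means a weaker inhibitor, a lower number a stronger inhibitor.
Compound 2 `O=S(=O)(Nc1ccc(F)c(C#Cc2cnc3[nH]nc(C4CC4)c3c2)c1F)c1cccnc1` gives 584 nM in this assay.
Compound 3 `O=S(=O)(Nc1ccc(F)c(C#Cc2cnc3[nH]nc(-c4ccccc4Cl)c3c2)c1F)c1cccnc1` reaches only the limit of the limit of > 10000 nM in this assay, at which 1 of the 3 values shown sits, in this assay, so for compound 3 the value > 10000 nM is a limit and not a number.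

Compound 3 therefore stands at the weak end of the three measured compounds, with only a bound known. Among the measured compounds shown here, the step of an at least 7.8-fold higher number from compound 1 to compound 3 (0.89 log units; beyond the scatter) and the step of an at least 17-fold higher number from compound 2 to compound 3 (1.23 log units; beyond the scatter) both run against the 2-chlorophenyl group, while the step of a 2.2-fold lower number from compound 1 to compound 2 (0.34 log units; beyond the scatter) is the only one that improves on compound 1.

Compound 4 `O=S(=O)(Nc1ccc(F)c(C#Cc2cnc3[nH]nc(-c4cccc(Cl)c4)c3c2)c1F)c1cccnc1` is the next compound. It differs from compound 3 by the change (3-chlorophenyl in place of 2-chlorophenyl on an aromatic carbon). For the measured compounds named here, no measured step moves a substituent around the phenyl ring, so only the steps onto the 2-chlorophenyl group bear on it, and they show that an aryl group at this place gives a large loss against compound 2 and an at least modest loss against compound 1.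

Compound 4 is expected to stay near the limit, with the step of a number no higher from compound 3 to compound 4 (the limit leaves the size open) estimated as small or none beyond the scatter. Compound 4 is estimated at 10000 nM, within 2500 nM to 40000 nM in this assay.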

Compound 4, half-maximal inhibitory concentration: > 10000 nM
Compound 4 was reported as a limit; the forecaster's own chance of this, stated with the estimate: 55%; the middle value lies on the limit itself.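

Compound 4, with the chlorine moved to give the 3-chlorophenyl group, joins compound 3 at a limit and not at a number: the limit of > 10000 nM in this assay, at which 2 of the 4 values shown sit.

The loss on this aromatic carbon is therefore not confined to the 2-chlorophenyl group, as the 3-chlorophenyl group also gives an at least 17-fold higher number from compound 2 to compound 4 (1.23 log units; beyond the scatter) and an at least 7.8-fold higher number from compound 1 to compound 4 (0.89 log units; beyond the scatter). Among the four compounds, both chlorophenyl groups stand against the smaller methoxy and cyclopropyl groups in this assay, but the step between the two chlorophenyl compounds cannot be read, so the two placements of the chlorine cannot be ranked.

Going by these compounds, how far either chlorophenyl compound lies beyond the limit remains unknown, and so does whether the chlorine plays any part in the loss. A phenyl group without chlorine, an amine or a longer alkyl chain on this aromatic carbon would show whether activity falls with the aryl ring itself or whether other groups can improve on compound 2, which gives 584 nM.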